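Notes on a Small Series and One Unmeasured Methyl Step

The source may hold more compounds than are shown below. What is called first, only, known or untested is meant among the compounds shown, and "the series" means these compounds.

Measured in a functional assay on XF498 cells (Homo sapiens) for inhibition, with a stated time of 72 h; on this read-out higher numbers stand for weaker inhibition and lower numbers for stronger inhibition:
compound 1 `CCCC1(c2ccccc2)CC(=O)C(C(CC(=O)c2ccc(-c3ccc(Br)cc3)cc2)c2ccccc2)=C(O)O1`, a limit of the assay: > 10000 nM
compound 2 `CC1(c2ccccc2)CC(=O)C(C2CC(c3ccc(OCc4ccc(C(F)(F)F)cc4)cc3)Cc3ccccc32)=C(O)O1`, a limit of the assay: > 10000 nM
compound 3 `COc1ccc(C2Cc3ccccc3C(C3=C(O)OC(C)(c4ccccc4)CC3=O)C2)cc1`, a limit of the assay: > 10000 nM

Compound 3 stands at the limit of > 10000 nM in this assay, at which 3 of the 3 values shown sit, and the two other values shown are the same limit, so its value in this assay is known only as a limit and not as a number. Among the measured compounds shown here, the one step within the measured set, from compound 2 to compound 3, is a step that the two limits leave unreadable from compound 2 to compound 3: the change there is hydrogen in place of 4-(trifluoromethyl)phenyl on a saturated chain carbon bound to an oxygen on an aromatic ring, and its size cannot be read from two limits.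

The next compound is compound 4 `CCC1(c2ccccc2)CC(=O)C(C2CC(c3ccc(OC)cc3)Cc3ccccc32)=C(O)O1`. It differs from compound 3 by methyl in place of hydrogen on a saturated chain carbon bound to a saturated ring carbon. For the measured compounds named here, no measured step in this assay touches this position, and the single step available gives no readable size. Nothing in the data therefore points to a shift beyond the scatter, and the expectation is that compound 4 in this assay is most likely reported as a limit again.

On that basis the step from compound 3 to compound 4 is expected to be a step that the limit leaves unreadable from compound 3 to compound 4. The value expected for compound 4 in this assay is 15000 nM, within a range from 4000 nM to 60000 nM.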

Compound 4, half-maximal inhibitory concentration: > 10000 nM
Compound 4 ended at the assay's limit (the forecaster's own chance of this, stated with the estimate: 85%); the middle value lies beyond the limit too.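

No size can be read for the change from compound 3 to compound 4 in this assay, since both results are limits and not numbers: the limit of > 10000 nM in this assay, at which 4 of the 4 values shown sit.

The compounds shown leave open how strongly any of them inhibits in this assay, and whether any change to these structures yields a readable value.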